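The compounds below may be only part of what the source reports. "The series", "measured", "known", "first", "only" and "open" are said of these compounds alone.

Measured so far, in an assay on isolated protein for inhibition of Amine oxidase [flavin-containing] B (Homo sapiens); a lower number here means a stronger inhibitor, a higher number a weaker inhibitor: compound 1 `O=C(/C=C/c1ccc(ON=C(c2ccccc2)c2ccccc2)cc1)c1ccc(F)cc1` gives only a limit, < 50 nM. Compound 2 `O=C(/C=C/c1ccc(Br)cc1)c1ccc(-n2ccnc2)cc1` gives 320 nM. Compound 3 `CCOc1ccc(C(=O)/C=C/c2ccc(Br)cc2)cc1` gives 210 nM.

Compound 3 holds the lowest of the two numbers, but its nearest neighbour is compound 2, and the step of a 1.5-fold lower number from compound 2 to compound 3 (0.18 log units; within the scatter) lies within the scatter, so the two cannot be ordered. Compound 4 `CCOc1ccc(C(=O)/C=C/c2ccc([N+](=O)[O-])cc2)cc1` differs from compound 3 by nitro in place of bromo on an aromatic carbon. Within the data shown here, the only measured step, a 1.5-fold lower number from compound 2 to compound 3 (0.18 log units; within the scatter), alters a different part of the core and so does not bear on this change. No step beyond the scatter in this assay is therefore expected; the step of a 1.2-fold higher number from compound 3 to compound 4 (0.08 log units; within the scatter) is estimated to be small. Compound 4 is expected to give 250 nM, within 80 nM to 800 nM.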

Compound 4, half-maximal inhibitory concentration: 210 nM
Beside the measured number, compound 4's estimate is 1.2-fold (0.08 log units) above it, within the range that was stated.
By their numbers in this assay, from the lowest: compounds 3, 4 and 2 (each within the scatter of the next). At a limit, below all of these: compound 1.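

In this assay, among these compounds, the first change at this aromatic carbon, para to a large group, shows no change at the digits printed from compound 3 to compound 4 (within the scatter) with nitro in place of bromo. Among the compounds shown here, the one earlier step altered a different part of the core, so only now is it seen that, with ethoxy held fixed, this position carries either group without a readable difference. Nothing in the data at hand accounts for this outcome. As far as these compounds go, whether an amine, a carboxylic acid or a longer chain at this position would leave the number unchanged remains open, as does whether nitro and bromo also match with 1H-imidazol-1-yl in place of ethoxy.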